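Trimming a side chain from compound 1 and its solubility

A few compounds are considered here, and "the series" means these few. Any claim that something is new, unique, unknown or untested is made for them only; others in the source may bear on it.

Of the compounds shown here, three have been measured in a physicochemical assay for solubility, in phosphate buffer, measured as kinetic solubility, with a stated time of 1 h, at pH 7.4; a lower number here means a less soluble compound, a higher number a more soluble compound. Compound 1 `CC(C)(c1cc([C@]23CCOC[C@H]2C3)nc(-c2cccc(O)c2)n1)S(C)(=O)=O` gives 135 ug/mL, its mirror image compound 2 `CC(C)(c1cc([C@@]23CCOC[C@@H]2C3)nc(-c2cccc(O)c2)n1)S(C)(=O)=O` gives 148 ug/mL, and compound 3 `CCNC(=O)Nc1ccc(-c2nccc([C@@]34CCOC[C@@H]3C4)n2)cc1` gives 127 ug/mL. Within these numbers compound 1 stands second highest, with compound 3 closest to it and compound 2 furthest, yet all three sit within the usual scatter of one another, so no order among them can be claimed.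

For the measured compounds named here, the only step between measured compounds that differ in one place is a 1.1-fold higher number from compound 1 to compound 2 (0.04 log units; within the scatter). It reflects the fact that compounds 1 and 2 differ only in the configuration as drawn and so says nothing about adding or removing a group.

Compound 4 `Oc1cccc(-c2nccc([C@]34CCOC[C@H]3C4)n2)c1` is not yet measured. Relative to compound 1 the change is hydrogen in place of 1-methyl-1-(methylsulfonyl)ethyl on an aromatic carbon. Going by the values given here, no measured step involves a change of this kind, so there is no precedent here to set a direction. Among the compounds with values here, the three numbers so far lie close together, which suggests that the shared core tolerates changes at its edge without large shifts in this assay. The expectation is therefore a step of a 1.1-fold higher number from compound 1 to compound 4 (0.05 log units; within the scatter), meaning no change beyond the scatter, with a wide margin for the unknown. Compound 4 is estimated at 150 ug/mL, in a range from 60 ug/mL to 350 ug/mL.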

Compound 4, solubility: 141 ug/mL
The estimate for compound 4 lay 1.1-fold (0.03 log units) above the measured number; the measured number falls inside the stated range.
By their numbers in this assay, from the lowest: compounds 3, 1, 4 and 2 (each within the scatter of the next).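

Taking the 1-methyl-1-(methylsulfonyl)ethyl group off the aromatic carbon and leaving a hydrogen there gives a 1.0-fold higher number from compound 1 to compound 4 (0.02 log units; within the scatter) in this assay. This is the first step among the compounds shown in which a group leaves rather than a configuration being inverted, and it shows that at this place, on an aromatic carbon of a six-membered aromatic ring with 2 nitrogen and next to the ring nitrogen, the loss of a chain of 7 heavy atoms with 2 hydrogen-bond acceptors cannot be told apart from the scatter of the read-out for this pair. Nothing at hand explains why the numbers of the two compounds agree.

With only hydrogen and this one chain shown at this place, it remains open whether an amine, a carboxylic acid or a longer chain there would also stay within the scatter of compound 1. As far as these compounds go, it also remains open whether the same exchange made on compound 2, the mirror image of compound 1, would give a step of similar size.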